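Arylpiperazine halogen swaps and serotonin receptor 7 binding

The compounds below may be only part of what the source reports. "The series", "measured", "known", "first", "only" and "open" are said of these compounds alone.

Compound 3 `CC1(c2ccc(F)cc2)NC(=O)N(CC(O)CN2CCN(c3ccc(Cl)cc3)CC2)C1=O` holds the highest of the three numbers in an assay on HEK293 cells for displacement of a labelled ligand from 5-hydroxytryptamine receptor 7 (Homo sapiens); on this read-out higher numbers stand for weaker inhibition and lower numbers for stronger inhibition: compound 3 gives 908 nM, whereas compound 1 `CC1(c2ccc(F)cc2)NC(=O)N(CC(O)CN2CCN(c3ccccc3)CC2)C1=O` gives 223 nM and compound 2 `CC1(c2ccc(F)cc2)NC(=O)N(CC(O)CN2CCN(c3ccccc3Cl)CC2)C1=O` gives 47 nM. Both chloro steps onto the aryl ring are beyond the scatter but opposite in sign, a 4.7-fold lower number from compound 1 to compound 2 (0.68 log units; beyond the scatter) against a 4.1-fold higher number from compound 1 to compound 3 (0.61 log units; beyond the scatter), and the direct comparison a 19-fold higher number from compound 2 to compound 3 (1.29 log units; beyond the scatter) is large. Compound 4 `CC1(c2ccc(F)cc2)NC(=O)N(CC(O)CN2CCN(c3ccc(F)cc3F)CC2)C1=O` carries the change (2,4-difluorophenyl in place of 4-chlorophenyl on an amine nitrogen in a ring). For the measured compounds named here, no measured step matches this exchange; the halogen pattern of 2,4-difluorophenyl combines features of compound 2 and compound 3, so a modest fall in this assay is expected, a 3.6-fold lower number from compound 3 to compound 4 (0.56 log units; beyond the scatter), rather than the large gain seen with compound 2. Compound 4 is estimated at 250 nM, within 70 nM to 900 nM.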

Compound 4, inhibition constant: 1190 nM
Beside the measured number, compound 4's estimate is 4.8-fold (0.68 log units) below it; measured number outside the range, above it.
By their numbers in this assay, from the lowest: compound 2; then compound 1; then compounds 3 and 4 (each within the scatter of the next).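

In this assay, 2,4-difluorophenyl in place of 4-chlorophenyl leaves the number unchanged within the scatter (a 1.3-fold higher number from compound 3 to compound 4 (0.12 log units; within the scatter)). The second fluorine arrangement does not reproduce the result of the 2-chlorophenyl group (a 25-fold higher number from compound 2 to compound 4 (1.40 log units; beyond the scatter)) and also falls short of plain phenyl (a 5.3-fold higher number from compound 1 to compound 4 (0.73 log units; beyond the scatter)), so among these halogenated compounds only compound 2 improves on compound 1. No measured evidence bears on this result.

Still open, from the compounds shown here alone, is whether 2-fluorophenyl or 2-methoxyphenyl on the same ring nitrogen would track compound 2 or compound 4.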